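Replacing a chloro substituent on the aryl ring of compound 2

The source may report more compounds than this note shows. Statements on the series, on what has been measured and on what is new or still open speak of the compounds shown alone.

Of the compounds shown here, two have been measured in a functional assay (brain) for displacement of a labelled ligand, with Rattus norvegicus as the target; a higher number here means a weaker inhibitor, a lower number a stronger inhibitor. Compound 1 `CCCC[C@]1(c2ccccc2)OC[C@H]([C@@H]2CCCCN2)O1` gives 200 nM, and compound 2 `CC[C@]1(c2cccc(Cl)c2)OC[C@H]([C@@H]2CCCCN2)O1` gives 59 nM, the lowest of the two numbers; the gap to compound 1 lies beyond the usual scatter. Compound 3 `CC[C@]1(c2cccc(N=C=S)c2)OC[C@H]([C@@H]2CCCCN2)O1` differs from compound 2 in one place: a group of 3 heavy atoms (1 carbon, 1 nitrogen, 1 sulfur; no ring) in place of one chlorine atom, on an aromatic carbon. Among the compounds with values here, no comparable step has been measured here, so the new group's effect is unknown. The author expects little change, with a small move toward a higher number in this assay, a 1.5-fold higher number from compound 2 to compound 3 (0.18 log units; within the scatter). Compound 3 is therefore estimated at 90 nM, within 30 nM to 300 nM.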

Compound 3, inhibition constant: 590 nM
Compound 3: middle estimate off by 6.6-fold (0.82 log units), on the low side, outside the stated range (above it).
By their numbers in this assay, from the lowest: compound 2; then compound 1; then compound 3.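

In this assay this aromatic position proves sensitive to what sits on it: putting the new group in place of chloro gives a 10-fold higher number from compound 2 to compound 3 (1.00 log units; beyond the scatter), a weakening beyond the usual scatter. Within the data shown here, this is the first step measured at this position, and it shows that chloro cannot be exchanged here for just any group without cost. Nothing available here explains the loss. As far as these compounds go, it remains open whether fluoro, methyl or an amine at this position would match compound 2, and whether the same exchange would cost as much with the butyl chain of compound 1 on the core.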